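The source may report more compounds than this note shows. Statements on the series, on what has been measured and on what is new or still open speak of the compounds shown alone.

Measured in an ADME assay on S9 fraction from liver (Rattus norvegicus) for metabolic stability, read by LC-MS, using NADPH, with a stated time of 30 min; on this read-out higher numbers stand for a more stable compound and lower numbers for a less stable compound:
Compound 1 `CCCCCCCCc1ccc(OCC(=O)Cn2nnc(C)n2)cc1`: < 5% (a limit)
Compound 2 `CCCCCCCCc1ccc(OCC(=O)Cn2nnc(SC)n2)cc1`: < 5% (a limit)
Compound 3 `CCCCCCCCc1ccc(OCC(=O)Cn2nnnc2SC)cc1`: 21%

Compound 3 is the only one of the three with a true number, the other two resting on (the limit of < 5% in this assay, at which 2 of the 3 values shown sit). The next change gives compound 4 `CCCCCCCCc1ccc(OCC(=O)Cn2nnnc2-c2ccncc2)cc1`, with pyridin-4-yl in place of methylsulfanyl on an aromatic carbon.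

Two measured steps lie beyond the scatter: a number at least 16 percentage points higher from compound 1 to compound 3 (beyond the scatter) and a number at least 16 percentage points higher from compound 2 to compound 3 (beyond the scatter). Both bring in 5-(methylsulfanyl)-1H-tetrazol-1-yl on a saturated chain carbon, so neither varies the group now being replaced. Among the compounds with values here, the only measured step on an aromatic carbon is a step that the two limits leave unreadable from compound 1 to compound 2. Within the data shown here, no measured step puts a ring at this place.

With compound 3 at 21% as the only anchor, no step beyond the scatter is expected in this assay, though the uncertainty is wide. The estimated change is a number 6 percentage points lower from compound 3 to compound 4 (within the scatter). For compound 4 the expected value is 15%, with an estimated range from 4% to 40%.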

Compound 4, percent of the compound remaining: 24%
Estimate against measurement, compound 4: 9 percentage points below, within the range that was stated.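

In this assay, pyridin-4-yl in place of methylsulfanyl on the aromatic carbon of the five-membered aromatic ring with 4 nitrogen gives a number 3 percentage points higher from compound 3 to compound 4 (within the scatter). Within the data shown here, this place therefore holds a six-membered aromatic ring with no readable change in the read-out, which the earlier compounds, none of them with a ring here, could not show. Nothing shown accounts for this outcome.

From the compounds shown here alone, what a phenyl ring, a pyridin-3-yl ring or an amine would give at this place stays open, so the part played by the ring nitrogen cannot be separated from that of the ring itself. Also open, going by these compounds, is how far the octyl chain shared by all four compounds governs the read-out, a question that a shorter chain or a terminal carboxylic acid would address.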